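The source may report more compounds than this note shows. Statements on the series, on what has been measured and on what is new or still open speak of the compounds shown alone.

Measured compounds in an ADME assay on microsomes from liver (Mus musculus) for metabolic stability; on this read-out lower numbers stand for slow clearance and higher numbers for fast clearance:

Compound 1 `O=C(Cc1nn(C2CCNC2)c(=O)c2ccccc12)Nc1ccc(OC(F)(F)F)c(Cl)c1` — 16300 mL/min/kg
Compound 2 `CC(C)(C(=O)O)c1nn(Cc2cn3cc(OCC4CC4)c(Cl)cc3n2)c2ccccc2c1=O` — in this assay compound 2 reports a limit, < 63.4 mL/min/kg
Compound 3 `COc1cc(OC)c(NC(=O)Cc2nn(CC(=O)O)c(=O)c3ccccc23)cc1Cl` — in this assay compound 3 reports a limit, < 55 mL/min/kg

Going by the values given here, compound 1 is the only member of the set with a numeric result in this assay, and that result places it as a very rapidly cleared compound. The two other values are limits of the assay, not numbers: compound 2 sits at the limit of < 63.4 mL/min/kg in this assay, at which 1 of the 3 values shown sits, and compound 3 sits at the limit of < 55 mL/min/kg in this assay, at which 1 of the 3 values shown sits, so both lie at the slow end of the read-out and cannot be ranked against each other.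

The step considered here leads from compound 1 to compound 4 `O=C(Cc1nn(CC(=O)N2CCOCC2)c(=O)c2ccccc12)Nc1ccc(OC(F)(F)F)c(Cl)c1`, an unmeasured compound with the shared core of compound 1 and the same anilide. The change is ((morpholin-4-yl)carbonyl)methyl in place of pyrrolidin-3-yl on an aromatic nitrogen. Among the compounds with values here, no measured pair of compounds shows the effect of this kind of exchange on the aromatic nitrogen, so the size of the step cannot be read off the data. Compound 3, which also carries a two-carbon substituent ending in a carbonyl on this nitrogen together with an anilide, reaches the limit in this assay; compound 1 with its pyrrolidin-3-yl is far from it. On that basis clearance for compound 4 is expected to fall toward slower clearance, with a step of a 5.4-fold lower number from compound 1 to compound 4 (0.74 log units; beyond the scatter) estimated for the exchange, while remaining well short of the limit. The estimate for compound 4 is 3000 mL/min/kg, within a range from 700 mL/min/kg to 10000 mL/min/kg.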

Compound 4, clearance: 11900 mL/min/kg
Compound 4: the middle estimate sits 4.0-fold (0.60 log units) below what was measured; the whole stated range lies below it.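

At this position, with the shared core and the anilide held constant, ((morpholin-4-yl)carbonyl)methyl in place of pyrrolidin-3-yl on the aromatic nitrogen gives a 1.4-fold lower number from compound 1 to compound 4 (0.14 log units; within the scatter) in this assay. Exchanging the five-membered ring with its hydrogen-bond donor for a six-membered ring, a carbonyl and no donor therefore does not separate compound 4 from compound 1, and both remain at the fast end of the read-out. No measured property among the compounds shown bears on this result.

No pair shown separates the contribution of the substituent on the aromatic nitrogen from that of the anilide. Also open, as far as these compounds go, is how a small methyl group, or a longer chain ending in a hydroxyl group, on this nitrogen would read with this anilide.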